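This account rests on a few compounds, and the source may have more. Where it says the series, first, only, none or still open, it means among the compounds named here.

Measured compounds:
- Compound 1, `COc1cccc(/C=C2\CCC/C(=C\c3ccc(Br)cc3)C2=O)c1OC`: > 20000 nM
- Compound 2, `COc1ccc(/C=C2\CCC/C(=C\c3cccc(Cl)c3)C2=O)cc1OC`: 11000 nM
- Compound 3, `COc1ccc(/C=C2\CCC/C(=C\c3cc(OC)c(OC)c(OC)c3)C2=O)cc1OC`: 2900 nM

In a functional assay on A549 cells (Homo sapiens) for cytotoxicity, read by MTT assay, with a stated time of 72 h (on this read-out lower numbers stand for stronger inhibition and higher numbers for weaker inhibition), compound 2 stands highest of the two numbers given. Compound 3 sits lower than compound 2 by a gap beyond the usual scatter. The value of compound 1 is a limit of this assay, not a number (the limit of > 20000 nM in this assay, at which 1 of the 3 values shown sits).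

Compound 4, `COc1ccc(/C=C2\CCC/C(=C\c3ccc(O)c(Cl)c3)C2=O)cc1OC`, has not yet been measured. It differs from compound 2 by hydroxy in place of hydrogen on an aromatic carbon. No measured step of this kind exists among these compounds, so any expectation rests on compound 2 alone. The expected step is a 1.4-fold lower number from compound 2 to compound 4 (0.14 log units; within the scatter), within the scatter, with no clear direction. Compound 4 is therefore estimated at 8000 nM, in a range from 3000 nM to 25000 nM.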

Compound 4, half-maximal inhibitory concentration: > 20000 nM
Compound 4 was reported as a limit (the forecaster's own chance of this, stated with the estimate: 25%); middle value at least 2.5-fold (0.39 log units) from the limit.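

In this assay compound 4 gives > 20000 nM and this is a limit of the assay, not a number. Placing hydroxy on this aromatic carbon, ortho to the chloro group and para to a large group, brings no gain in cytotoxicity, with an at least 1.8-fold higher number from compound 2 to compound 4 (0.25 log units; that floor lies within the scatter) as the step that can be read. The reading for compound 4 now stands at the same limit as one other compound in the set: the limit of > 20000 nM in this assay, at which 2 of the 4 values shown sit. As far as these compounds go, how far this change really raises the number stays open, since only its floor is known. Also open, from the compounds shown here alone, is whether an amine or a carboxylic acid on this same carbon would give a lower number than hydroxy.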